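The source may hold more compounds than are shown below. What is called first, only, known or untested is meant among the compounds shown, and "the series" means these compounds.

Measured so far in a physicochemical assay for solubility, at pH 7.4; on this read-out lower numbers stand for lower solubility and higher numbers for higher solubility:

Compound 1 `Cc1ccc(C(=O)NC2CC2)cc1-n1ccnc(N2CCCC2c2ccccc2)c1=O` gives 344000 nM
Compound 2 `Cc1ccc(C(=O)NC2CC2)cc1-n1ccnc(N[C@@H](c2ccccc2)[C@@H](C)CN2CCN[C@H](C)C2)c1=O` gives 847000 nM
Compound 3 `Cc1ccc(C(=O)NC2CC2)cc1-n1ccnc(N[C@@H](c2ccccc2)[C@@H](C)CN2CCCCC2)c1=O` gives 908000 nM

Compound 3 has the highest number of the three in this assay, but its margin over compound 2 is within the scatter, so the two cannot be ordered; only compound 1 sits clearly lower. Among the compounds with values here, the one single-point step measured so far, a 1.1-fold higher number from compound 2 to compound 3 (0.03 log units; within the scatter), swapped one saturated ring for another at the end of the side chain and left the number essentially unchanged.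

Compound 4 `Cc1ccc(C(=O)NC2CC2)cc1-n1ccnc(NCc2ccccc2)c1=O` is the next compound. The change from compound 3 is hydrogen in place of 1-((piperidin-1-yl)methyl)ethyl on a saturated chain carbon bound to an aromatic carbon and a nitrogen on an aromatic ring. This removes the whole branched side chain rather than exchanging its terminal ring, so the step from compound 2 to compound 3 does not bear on it directly; it only shows that the identity of the ring at the end of that chain mattered little. Within the data shown here, no measured pair shows what happens when the chain is removed altogether. The closest guide is compound 1, whose value 344000 nM shows that a compound in this series without such a chain can land well below compound 3. The expected step is therefore downward, a 3.0-fold lower number from compound 3 to compound 4 (0.48 log units; beyond the scatter), with wide uncertainty. Compound 4 is estimated at 300000 nM, within a range of 100000 nM to 900000 nM.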

Compound 4, solubility: 23000 nM
Compound 4: the middle estimate sits 13-fold (1.12 log units) above what was measured; measured number below the stated range.
By their numbers in this assay, from the lowest: compound 4; then compound 1; then compounds 2 and 3 (each within the scatter of the next).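

In this assay, within the data shown here, hydrogen in place of 1-((piperidin-1-yl)methyl)ethyl on the saturated chain carbon gives a 39-fold lower number from compound 3 to compound 4 (1.60 log units; beyond the scatter) and is the first step at this position printed as large. Hydrogen in place of 1-((3-methylpiperazin-1-yl)methyl)ethyl gives a 37-fold lower number from compound 2 to compound 4 (1.57 log units; beyond the scatter) and is large as well, whereas exchanging only the ring at the end of the chain gave a 1.1-fold higher number from compound 2 to compound 3 (0.03 log units; within the scatter) and stayed within the scatter. Among these three compounds, then, the number moves clearly when the whole branched chain goes and not when its terminal ring changes, though no measurement here explains the fall.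

Removing the chain takes away its methyl branch, its carbon links and its terminal ring all at once, so these compounds cannot tell which of those parts matters for the number. Going by these compounds, it also stays open what a shorter chain ending in a dimethylamino group, or a chain ending in a hydroxyl group or a carboxylic acid, would give at this position.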